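Extending a Saturated Chain on a Tetrazole Urea

The source may report more compounds than this note shows. Statements on the series, on what has been measured and on what is new or still open speak of the compounds shown alone.

Compound 1, `CC(C)c1cccc(C(C)C)c1NC(=O)Nc1nn[nH]n1`, gives in an assay on microsomes from intestine for inhibition of acyl-CoA:cholesterol acyltransferase (Oryctolagus cuniculus) (on this read-out lower numbers stand for stronger inhibition and higher numbers for weaker inhibition), only a limit, > 10000 nM (the limit of > 10000 nM in this assay, at which 1 of the 3 values shown sits). Compound 2, `CC(C)c1cccc(C(C)C)c1NC(=O)NC1=NN(Cc2ccccc2)NN1`, gives 370 nM in this assay. Compound 3, `CCCCCCCCN1NN=C(NC(=O)Nc2c(C(C)C)cccc2C(C)C)N1`, gives 59 nM in this assay, the lowest of the two numbers shown, with compound 2 next above it by a gap beyond the usual scatter. Compound 4, `CCCCCCCCCCCN1NN=C(NC(=O)Nc2c(C(C)C)cccc2C(C)C)N1`, is not yet measured and differs from compound 3 in one place: propyl in place of hydrogen on a saturated chain carbon, eight bonds along the chain from an amine nitrogen in a ring. Among the measured compounds shown here, no pair of measured compounds differs by such a chain extension alone, so the size of this step is open from the data. Since compound 3 already gives 59 nM, the expectation is a small lowering or none beyond the scatter, that is, a step of a 1.5-fold lower number from compound 3 to compound 4 (0.17 log units; within the scatter) is expected. Compound 4 is therefore estimated at 40 nM, within a range from 15 nM to 120 nM.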

Compound 4, half-maximal inhibitory concentration: 9 nM
Beside the measured number, compound 4's estimate is 4.4-fold (0.65 log units) above it; measured number below the stated range.
By their numbers in this assay, from the lowest: compound 4; then compound 3; then compound 2. At a limit, above all of these: compound 1.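

In this assay, among the compounds shown here, this chain position had no measured step until now, and the first one is clear: propyl in place of hydrogen on a saturated chain carbon, eight bonds along the chain from an amine nitrogen in a ring, gives a 6.6-fold lower number from compound 3 to compound 4 (0.82 log units; beyond the scatter). So even this far along the chain, a change of 3 heavy atoms, all carbon, with no ring, no hydrogen-bond donors or acceptors and no net charge, moves the number beyond the scatter. Nothing measured among the compounds shown accounts for the size of this step.

On these data alone, a single step sets no trend, so whether a still longer chain would lower the number further or raise it stays open. Also open, as far as these compounds go, is how this position would respond to a chain ending in an amine or a carboxylic acid.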